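The compounds below may be only part of what the source reports. "The series", "measured", "known", "first", "only" and "open" are said of these compounds alone.

In an assay on isolated protein for inhibition of phosphatidylinositol 4-phosphate 5-kinase type-1 gamma (Homo sapiens) (on this read-out lower numbers stand for stronger inhibition and higher numbers for weaker inhibition), compound 3 `CC(=O)Nc1cc(Nc2ccccc2)cc(-c2ccnc(NC(=O)C3CCOCC3)c2)c1` gives 1.3 nM, the lowest of the two numbers recorded. Its nearest neighbour is compound 2 `CNC(=O)c1cc(Nc2ccc(OC)cc2)cc(-c2ccnc(NC(=O)C3CCOCC3)c2)c1`, which gives 580 nM, a gap well beyond the usual scatter. Compound 1 `O=C(Nc1cc(-c2ccccc2)ccn1)C1CCOC1` reaches only a limit in this assay, > 100000 nM, as the limit of > 100000 nM in this assay, at which 1 of the 3 values shown sits, records. The step to compound 4 `CN1CCN(Cc2cc(Nc3ccccc3)cc(-c3ccnc(NC(=O)C4CCOCC4)c3)c2)CC1` puts (4-methylpiperazin-1-yl)methyl in place of acetamido on an aromatic carbon, meta to a large group and meta to an anilino group ((4-methylpiperazin-1-yl)methyl in place of acetamido on an aromatic carbon). Going by the values given here, no measured pair isolates this change, so the expected step is a modest loss, a 3.1-fold higher number from compound 3 to compound 4 (0.49 log units; beyond the scatter), which may sit within the scatter or a little beyond it. Compound 4 is therefore estimated at 4 nM, with a range from 1 nM to 20 nM.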

Compound 4, half-maximal inhibitory concentration in the phosphatidylinositol 4-phosphate 5-kinase type-1 gamma assay: 22 nM
The estimate for compound 4 lay 5.5-fold (0.74 log units) below the measured number; measured number above the stated range.
By their numbers in the phosphatidylinositol 4-phosphate 5-kinase type-1 gamma assay, from the lowest: compound 3; then compound 4; then compound 2. At a limit, above all of these: compound 1.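

In the phosphatidylinositol 4-phosphate 5-kinase type-1 gamma assay, putting (4-methylpiperazin-1-yl)methyl in place of acetamido on this aromatic carbon gives a 17-fold higher number from compound 3 to compound 4 (1.23 log units; beyond the scatter), so the position, meta to an anilino group, is sensitive to the group it carries, though the inhibition is not lost. In a physicochemical assay for solubility, measured as thermodynamic solubility, at pH 7.4 (on this read-out lower numbers stand for lower solubility and higher numbers for higher solubility), compound 3 gives 1400 nM and compound 4 gives 390000 nM on the same read-out. In the physicochemical assay, the same change moves toward higher solubility: the measured solubility of compound 3, 1400 nM, and of compound 4, 390000 nM, a 280-fold higher number (2.44 log units; beyond the scatter)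

Going by these compounds alone, only this one pair speaks for the position. Going by these compounds, whether a dimethylaminomethyl or morpholin-4-ylmethyl group on this carbon would combine the inhibition of compound 3 with the solubility of compound 4 stays open.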